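The compounds below may be only part of what the source reports. "The series", "measured", "known", "first", "only" and "open" are said of these compounds alone.

Measured compounds: compound 1 `O=C(Nn1c(-c2cccc([N+](=O)[O-])c2)nc2c(-c3ccc(Cl)cc3)n[nH]c2c1=O)c1cccnc1`, in a functional assay on A549 cells (Homo sapiens) for cytotoxicity, read by sulforhodamine B assay, with a stated time of 2 days, tested at 100 uM (a higher number here means more inhibition at the concentration tested (going by the name of the read-out), a lower number less inhibition), compound 1 gives 19.7%; compound 2 `CCCc1n[nH]c2c(=O)n(NC(=O)c3ccccc3)c(-c3cccc([N+](=O)[O-])c3)nc12`, in this assay compound 2 gives 33.2%; compound 3 `O=C(Nn1c(-c2cccc([N+](=O)[O-])c2)nc2c(-c3cccc(Cl)c3)n[nH]c2c1=O)c1ccccc1`, for which the result in this assay for compound 3 is "not determined" (no result reported).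

Compound 3 therefore stands without a number, and its place among the others cannot be read off. Compound 4 `O=C(Nn1c(-c2cccc([N+](=O)[O-])c2)nc2c(-c3ccc(Cl)cc3)n[nH]c2c1=O)c1ccccc1` differs from it by one rearrangement: 4-chlorophenyl in place of 3-chlorophenyl on an aromatic carbon. For the measured compounds named here, since compound 3 has no value, no step in this assay can be drawn, and no size or direction beyond the usual scatter is expected. Compound 4 shares its 4-chlorophenyl with compound 1, whose value is 19.7%, while compound 2 gives 33.2%. On that basis compound 4 is expected to give about 26%, estimated between 8% and 44%.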

Compound 4, a percentage reported as inhibition, at one concentration (the size of the read-out at that concentration, not a potency): 88.6%
The estimate for compound 4 lay 62.6 percentage points below the measured number; measured number above the stated range.
By their numbers in this assay, from the lowest: compound 1; then compound 2; then compound 4.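

In this assay, 4-chlorophenyl in place of propyl on an aromatic carbon gives a number 55.4 percentage points higher from compound 2 to compound 4 (beyond the scatter) and phenyl in place of pyridin-3-yl on a carbonyl carbon gives a number 68.9 percentage points higher from compound 1 to compound 4 (beyond the scatter) in the same compound. The 4-chlorophenyl alone does not set the high number, since compound 1 carries it too and stays low; the group on the carbonyl carbon also matters. Nothing available here accounts for either step.

As far as these compounds go, the step between compound 3 and compound 4 cannot be read, so what 3-chlorophenyl gives against 4-chlorophenyl stays open. Also open, from the compounds shown here alone, is whether an amine on the phenyl at the carbonyl carbon would keep the number of compound 4.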